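The source may hold more compounds than are shown below. What is called first, only, known or untested is meant among the compounds shown, and "the series" means these compounds.

Series notes. Three compounds have been run in an assay on nucleic acid for inhibition of Nucleic Acid, read by fluorescence, tested at 100 uM (a lower number here means less inhibition, a higher number more inhibition at the concentration tested (going by the name of the read-out)), so far. Compound 3 `CC(C)CCN(C)Cc1cn(C2CCCCC2OC(=O)c2ccccc2)nn1` gives 26% in this assay. Compound 1 `CC(C)CCN(C)Cc1cn(C2CCCCC2OC(=O)COc2ccccc2)nn1` differs from compound 3 by one change, (phenoxymethyl in place of phenyl on a carbonyl carbon), and in this assay compound 1 gives 59%; the step of a number 33 percentage points higher from compound 3 to compound 1 (beyond the scatter) is the one well-defined move in the set so far. Compound 2 `O=C(OC1CCCCC1n1cc(CN2CCN(c3ccccc3)CC2)nn1)c1ccccc1` carries a different core; the difference between the core of compound 2 and the core of compound 3 is not broken down here. In this assay compound 2 gives 21%, and the values of compound 2 and compound 3 lie within the scatter of each other.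

Compound 4 `O=C(COc1ccccc1)OC1CCCCC1n1cc(CN2CCN(c3ccccc3)CC2)nn1` is the next compound to be measured. Against compound 2 it shows (phenoxymethyl in place of phenyl on a carbonyl carbon), which is the same change as the one from compound 3 to compound 1, made on the other core. Among the compounds with values here, since the place of the change reads the same in both pairs, the earlier step is the only guide. The step from compound 2 to compound 4 in this assay is expected to be a number 29 percentage points higher from compound 2 to compound 4 (beyond the scatter), resting on the step seen from compound 3 to compound 1, a number 33 percentage points higher from compound 3 to compound 1 (beyond the scatter), with a broad range because the change has been seen only once and on a different core. For compound 4 the expected value in this assay is 50%, with a range from 25% to 75%.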

Compound 4, a percentage reported as inhibition, at one concentration (the size of the read-out at that concentration, not a potency): 37%
Compound 4: the middle estimate sits 13 percentage points above what was measured; the range from low to high includes it.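

In this assay, phenoxymethyl in place of phenyl on a carbonyl carbon raises the number on the second core as well, the step being a number 16 percentage points higher from compound 2 to compound 4 (beyond the scatter), so the direction of the change is the same on both cores shown. The size does not carry over, and a step read on one core cannot be transferred as a fixed amount to the other: the same change on two cores in this assay, a number 33 percentage points higher (beyond the scatter) from compound 3 to compound 1 and a number 16 percentage points higher (beyond the scatter) from compound 2 to compound 4, 17 percentage points apart, beyond the scatter of two such steps. Within the data shown here, with only two pairs, this shows neither what sets the size of the step on each core nor whether the same direction would hold on any further core.

Phenoxymethyl differs from phenyl by both an added carbon and an added oxygen, so the compounds shown do not separate the two; a benzyl group on the carbonyl carbon would carry the added carbon without the oxygen, and a longer chain such as phenoxyethyl would test the length of the link. Also open, from the compounds shown here alone, is whether the ester itself is needed, since an amide in its place, on either core, would show whether the step depends on that oxygen next to the carbonyl group.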